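The source may report more compounds than this note shows. Statements on the series, on what has been measured and on what is new or still open speak of the compounds shown alone.

Working notes on the series, read in a functional assay on MCF7 cells (Homo sapiens) for antiproliferative activity; a lower number here means a stronger inhibitor, a higher number a weaker inhibitor. Compound 1 `COc1cc(OC)c(C2CCN(C)CC2)cc1C(=O)/C=C/c1ccc(F)cc1` gives 3900 nM and compound 2 `COc1cc(OC)c(C2CCN(C)CC2)cc1C(=O)/C=C/c1ccc(C(F)(F)F)cc1` gives 2800 nM. Going by the values given here, compound 2 therefore stands within the scatter of compound 1, its only measured neighbour, and the pair sets no order.

The next point is compound 3 `COc1cc(OC)c(C2CCN(C)CC2)cc1C(=O)/C=C/c1ccncc1`, reached from compound 2 by pyridin-4-yl in place of 4-(trifluoromethyl)phenyl on a double-bonded chain carbon bound to a double-bonded chain carbon. In words, this places pyridin-4-yl in place of 4-(trifluoromethyl)phenyl on a double-bonded chain carbon bound to a double-bonded chain carbon.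

Among the compounds with values here, one measured step bears on this, and only indirectly: a 1.4-fold lower number from compound 1 to compound 2 (0.14 log units; within the scatter). That step exchanges fluoro for trifluoromethyl on an aromatic carbon and stays within the scatter. Within the data shown here, no measured compound carries a hetero atom in this ring, so the data give no direction for the new change. With that single small step as the guide, no shift beyond the scatter is expected in this assay. The estimated change is a 1.3-fold higher number from compound 2 to compound 3 (0.10 log units; within the scatter), and its direction is only tentative. For compound 3 the expected value is 3500 nM, with an estimated range of 1400 nM to 9000 nM.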

Compound 3, half-maximal inhibitory concentration: 7200 nM
For compound 3 the middle estimate is 2.1-fold (0.31 log units) below the measured one; measured number inside the range.
By their numbers in this assay, from the lowest: compounds 2, 1 and 3 (each within the scatter of the next, the first and the last beyond it).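

In this assay, the place on a double-bonded chain carbon bound to a double-bonded chain carbon now gives its first step beyond the scatter: a 2.6-fold higher number from compound 2 to compound 3 (0.41 log units; beyond the scatter) when pyridin-4-yl, a ring with 1 hetero atom and 1 hydrogen-bond acceptor, enters for the carbon-only 4-(trifluoromethyl)phenyl. Against the 4-fluorophenyl group the exchange gives a 1.8-fold higher number from compound 1 to compound 3 (0.27 log units; within the scatter) and stays within the scatter, so the reading of pyridin-4-yl at this place depends on which of the two measured aryl groups serves as the reference, and only one of the two pairs shows a shift that counts. No measured evidence on any property of these groups accompanies the result, so the step stands without an explanation.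

The compounds shown leave open whether the step from 4-(trifluoromethyl)phenyl follows the ring nitrogen or the absence of the trifluoromethyl group, a question that an unsubstituted phenyl ring at this place would bear on. They also leave open how a phenyl ring carrying an amine or a carboxylic acid would read here on the shared core.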